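Replacing a urea linker by an amide in a pyrazole series

The source may hold more compounds than are shown below. What is called first, only, known or untested is meant among the compounds shown, and "the series" means these compounds.

Of the compounds shown here, two of a shared core have been measured in a functional assay on LOX IMVI cells (Homo sapiens) for inhibition, read by sulforhodamine B assay, with a stated time of 48 h, tested at 1 uM; on this read-out higher numbers stand for a weaker effect at the one concentration tested and lower numbers for a stronger effect. Compound 1, `COc1cc(Cl)cc(-c2nn(-c3cccc(NC(=O)Nc4ccc(Cl)c(Cl)c4)c3)cc2-c2ccncc2)c1`, gives 91% in this assay. Compound 2, `COc1cc(Cl)cc(-c2nn(-c3cccc(NC(=O)Nc4cccc(C(F)(F)F)c4)c3)cc2-c2ccncc2)c1`, gives 72% in this assay, which is the lowest of the two numbers and therefore the stronger effect of the pair. Among the compounds with values here, the single step between them, a number 19 percentage points lower from compound 1 to compound 2 (beyond the scatter), came from changing the aryl group on the amide-type nitrogen.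

Compound 3, `COc1cc(Cl)cc(-c2nn(-c3cccc(NC(=O)c4cccc(C(F)(F)F)c4)c3)cc2-c2ccncc2)c1`, is not yet measured. It differs from compound 2 by 3-(trifluoromethyl)phenyl in place of (3-(trifluoromethyl)phenyl)amino on a carbonyl carbon, so the urea becomes an amide and one hydrogen-bond donor is lost. Within the data shown here, no measured step touches this part of the molecule; the only step known concerns a different change, and its size offers no direct guide here. The expectation for compound 3 is therefore uncertain, with a modest weakening as the more likely outcome, expressed as a number 8 percentage points higher from compound 2 to compound 3 (within the scatter). In this assay compound 3 is estimated at 80%, within a range from 60% to 98%.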

Compound 3, a percentage reported as activity, at one concentration (the size of the read-out at that concentration, not a potency): 88%
Compound 3: the middle estimate sits 8 percentage points below what was measured, and the stated range covers the measured number.
By their numbers in this assay, from the lowest: compound 2; then compounds 3 and 1 (each within the scatter of the next).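

In this assay, the link itself turns out to matter, not just the aryl group at its end: attaching 3-(trifluoromethyl)phenyl directly to the carbonyl carbon, in place of (3-(trifluoromethyl)phenyl)amino, gives a number 16 percentage points higher from compound 2 to compound 3 (beyond the scatter), which means a weaker effect at the one concentration tested. This change removes a nitrogen and its hydrogen-bond donor while the aromatic ring and the trifluoromethyl group remain, and the step of a number 3 percentage points lower from compound 1 to compound 3 (within the scatter) shows that the amide compound 3 cannot be told apart from the 3,4-dichlorophenyl urea compound 1. Nothing available here explains why the loss of that nitrogen is accompanied by a weaker effect.

The compounds shown leave open whether a carbamate, with an oxygen in place of that nitrogen, or a sulfonamide, with a sulfonyl group in place of the carbonyl, would match the urea of compound 2 or fall back towards the amide of compound 3. They also leave open how a 3,4-dichlorophenyl group would behave on the amide, which would show whether the choice of aryl group still counts once the urea is gone.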